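The source may hold more compounds than are shown below. What is called first, only, known or untested is meant among the compounds shown, and "the series" means these compounds.

Compound 1 `O=C1COc2ccc(-c3cnc4ccccc4c3)cc2N1c1ccccc1` gives > 40000 nM in a functional assay on HCT-116 cells (Homo sapiens) for antiproliferative activity, read by MTT assay, with a stated time of 72 h; a lower number here means a stronger inhibitor, a higher number a weaker inhibitor.
Compound 2 `O=C1COc2ccc(-c3cnc(Cl)c(NS(=O)(=O)c4ccc(F)cc4)c3)cc2N1C1CCCCC1` gives > 40000 nM in this assay.

Both of these are limits of the assay, not measured numbers. Compound 1 therefore stands at the limit, where every value shown sits (the limit of > 40000 nM in this assay, at which 2 of the 2 values shown sit). Compound 3 `O=C1COc2ccc(-c3cnc4ccccc4c3)cc2N1C1CCCCC1` differs from compound 1 by cyclohexyl in place of phenyl on an amide-type nitrogen in a ring. Compound 2 carries a cyclohexyl on the same amide-type nitrogen and also gives only a limit. Among the measured compounds shown here, no measured step connects any two compounds, so the change from compound 1 to compound 3 is expected to bring no shift beyond the scatter. Compound 3 is expected at about 50000 nM, between 15000 nM and 200000 nM, most likely reported again as a limit. That expectation means a step that the limit leaves unreadable from compound 1 to compound 3.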

Compound 3, half-maximal inhibitory concentration: > 40000 nM
Compound 3 ended at the assay's limit; the forecaster's own chance of this, stated with the estimate: 75%; the middle value lies beyond the limit too.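

Compound 1 and compound 3 both end at a limit rather than a measured number, so no step can be read between them: the limit of > 40000 nM in this assay, at which 3 of the 3 values shown sit. In this assay the compounds shown leave open whether phenyl or cyclohexyl on that nitrogen makes any difference.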